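Amide-to-ester change at the carbonyl of the shared core

The source may hold more compounds than are shown below. What is called first, only, known or untested is meant among the compounds shown, and "the series" means these compounds.

Measured so far:
compound 1, `Nc1sc(-c2ccc(Cl)cc2)c(-c2ccc(Cl)cc2)c1C(=O)NC1CCCCC1`, 590 nM
compound 2, `Nc1sc(-c2ccc(Cl)cc2)c(-c2ccc(Cl)cc2)c1C(=O)Nc1ccccc1`, 14500 nM

Both numbers come from a functional assay on HCT-116 cells (Homo sapiens) for cytotoxicity, read by sulforhodamine B assay, with a stated time of 72 h; on this read-out lower numbers stand for stronger inhibition and higher numbers for weaker inhibition. Going by the values given here, compound 2 holds the higher of the two numbers; its only neighbour is compound 1, and the step between them is a 25-fold higher number from compound 1 to compound 2 (1.39 log units; beyond the scatter). Compound 3, `COC(=O)c1c(N)sc(-c2ccc(Cl)cc2)c1-c1ccc(Cl)cc1`, has not yet been measured. It differs from compound 2 as follows: methoxy in place of anilino on a carbonyl carbon. Among the compounds with values here, no measured pair covers this change directly; the single measured step, a 25-fold higher number from compound 1 to compound 2 (1.39 log units; beyond the scatter), shows only that what sits on the carbonyl carbon can move the number a long way. Since the anilino group carried by the weaker compound 2 leaves, a lower number is expected for compound 3, though its size is uncertain, so the expected step is a 4.1-fold lower number from compound 2 to compound 3 (0.62 log units; beyond the scatter). Compound 3 is therefore estimated at 3500 nM, within a range of 600 nM to 20000 nM.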

Compound 3, half-maximal inhibitory concentration: 1660 nM
The estimate for compound 3 lay 2.1-fold (0.32 log units) above the measured number; the measured number falls inside the stated range.
By their numbers in this assay, from the lowest: compound 1; then compound 3; then compound 2.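

In this assay, methoxy in place of anilino on the carbonyl carbon gives an 8.7-fold lower number from compound 2 to compound 3 (0.94 log units; beyond the scatter), so the amide nitrogen and its hydrogen are not needed for a number in this range. Methoxy in place of cyclohexylamino gives a 2.8-fold higher number from compound 1 to compound 3 (0.45 log units; beyond the scatter), which places the ester between the two amides, with one amide lower and the other higher, so the change from amide to ester does not by itself set the direction of the step; what counts in this set of three is which group replaces methoxy. Nothing available explains these differences between the groups on the carbonyl carbon.

Open, as far as these compounds go, is whether a carboxylic acid, or a longer ester such as ethyl or butyl, would follow the methoxy result. Also open, from the compounds shown here alone, is whether a cyclopentylamino or benzylamino group on the carbonyl carbon would stay nearer to compound 1 or to compound 2.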